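The source may report more compounds than this note shows. Statements on the series, on what has been measured and on what is new or still open speak of the compounds shown alone.

Of the compounds shown here, three built on one shared core have been measured. In an assay for inhibition of Thromboxane-A synthase (Homo sapiens), using microsomes (a higher number here means a weaker inhibitor, a lower number a stronger inhibitor), compound 1 `O=C(O)CC/C=C\CC1COC(c2ccc(Cl)cc2Cl)OC1c1cccnc1` gives 42 nM. Compound 2 `Cc1ccc(C#N)c(OC(C)(C)C2OCC(C/C=C\CCC(=O)O)C(c3cccnc3)O2)c1` gives 50 nM in this assay. Compound 3 `CC(C)(C)c1ccc(OC(C)(C)C2OCC(C/C=C\CCC(=O)O)C(c3cccnc3)O2)cc1` gives 280 nM in this assay, the highest of the three numbers. Within the data shown here, the only single-place step among the measured compounds is a 5.6-fold higher number from compound 2 to compound 3 (0.75 log units; beyond the scatter), so the aryl group on that oxygen clearly matters. Compound 4 `COc1ccccc1OC(C)(C)C1OCC(C/C=C\CCC(=O)O)C(c2cccnc2)O1` differs from compound 3 by 2-methoxyphenyl in place of 4-(tert-butyl)phenyl on an oxygen on a saturated carbon, a change at the same oxygen. Because the step of a 5.6-fold higher number from compound 2 to compound 3 (0.75 log units; beyond the scatter) was modest and ran upward toward compound 3, the reverse kind of change is expected to bring the number back down, and compound 4 is expected to show a 3.5-fold lower number from compound 3 to compound 4 (0.54 log units; beyond the scatter), landing at about 80 nM with a likely range from 30 nM to 250 nM.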

Compound 4, half-maximal inhibitory concentration: 60 nM
Compound 4: the middle estimate sits 1.3-fold (0.12 log units) above what was measured; measured number inside the range.
By their numbers in this assay, from the lowest: compounds 1, 2 and 4 (each within the scatter of the next); then compound 3.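

In this assay, the step back from the 4-(tert-butyl)phenyl group is a 4.7-fold lower number from compound 3 to compound 4 (0.67 log units; beyond the scatter), while a 1.2-fold higher number from compound 2 to compound 4 (0.08 log units; within the scatter). So two different aryl groups on this oxygen, 2-methoxyphenyl and 2-cyano-5-methylphenyl, give values that cannot be told apart, and among these three compounds only 4-(tert-butyl)phenyl stands out with a higher number. Nothing available explains this difference. The compounds shown leave open how an unsubstituted phenyl, or a group without a ring such as a longer chain or an amine, would behave on this oxygen.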